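The source may report more compounds than this note shows. Statements on the series, on what has been measured and on what is new or still open speak of the compounds shown alone.

Measured compounds:
Compound 1 `Cc1nc2c3ccccc3ccc2c2nc3c(ccc4ccccc43)c(-c3cccc([N+](=O)[O-])c3)c12` — 117 ug/mL in a functional assay, read by spectrophotometry, with a stated time of 30 min; on this read-out lower numbers stand for stronger inhibition and higher numbers for weaker inhibition
Compound 2 `COc1ccc(-c2c3ccc4ccccc4c3nc3c2c(C)nc2c4ccccc4ccc32)cc1` — 133 ug/mL in this assay

Among the measured compounds shown here, compound 2 sits alongside compound 1 in this assay; the one step joining them, a 1.1-fold higher number from compound 1 to compound 2 (0.06 log units; within the scatter), lies within the scatter, so the two numbers cannot be told apart. Compound 3 `Cc1nc2c3ccccc3ccc2c2nc3c(ccc4ccccc43)c(-c3ccccc3S)c12` is the next member and is not yet measured. Its difference from compound 2 is 2-sulfanylphenyl in place of 4-methoxyphenyl on an aromatic carbon. For the measured compounds named here, the single measured step, from compound 1 to compound 2, concerns a different pair of groups and shows no movement beyond the scatter; nothing measured bears directly on a 2-sulfanylphenyl group. With that, the expectation is no step beyond the scatter, expressed as a 1.1-fold lower number from compound 2 to compound 3 (0.03 log units; within the scatter). The estimate for compound 3 in this assay is therefore 125 ug/mL, expected to fall between 60 ug/mL and 260 ug/mL.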

Compound 3, half-maximal inhibitory concentration: 89 ug/mL
Compound 3: middle estimate off by 1.4-fold (0.15 log units), on the high side; measured number inside the range.
By their numbers in this assay, from the lowest: compounds 3, 1 and 2 (each within the scatter of the next).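

In this assay, a third aryl group at the position opposite the ring nitrogen gives no reading that can be told apart from the earlier two: a 1.5-fold lower number from compound 2 to compound 3 (0.17 log units; within the scatter) and a 1.3-fold lower number from compound 1 to compound 3 (0.12 log units; within the scatter). The earlier pair showed this only for 3-nitrophenyl and 4-methoxyphenyl, whereas 2-sulfanylphenyl extends it to a group with sulfur and a hydrogen-bond donor, and neither feature produces a step beyond the scatter. No independent measurement bears on this result.

Because each of the three aryl groups differs in both its substituent and where that substituent sits on the phenyl ring, these two variables remain unseparated. Also open, on these data alone, is whether an amine or a carboxylic acid on that ring, or a longer chain in its place, would move the number beyond the scatter.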